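A few compounds are considered here, and "the series" means these few. Any claim that something is new, unique, unknown or untested is made for them only; others in the source may bear on it.

Compound 1, with the structure `C=C[C@@](C)(/C=C/c1ccc(OC)cc1)CCC=C(C)C`, is the starting point. In a functional assay on NALM-6 cells (Homo sapiens) for cytotoxicity, with a stated time of 72 h (on this read-out lower numbers stand for an effect already at smaller amounts and higher numbers for an effect only at larger amounts of compound), compound 1 gives only a limit of the assay, > 43400 nM. Compound 2, `C=C[C@@](C)(/C=C/c1ccc(O)cc1)CC/C=C(C)/C=C/C(=O)OCC`, gives 815 nM in this assay. Compound 3, `C=C[C@@](C)(/C=C/c1ccc(O)c(/C=C/C=C/c2ccccc2)c1)CCC=C(C)C`, again gives only a limit of the assay, > 43400 nM, in this assay. Two of the three values shown therefore sit at the same limit, as summed up in the limit of > 43400 nM in this assay, at which 2 of the 3 values shown sit, and compound 1 is one of them; only compound 2 yields a number.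

The compound still to be measured is compound 4, `C=C[C@@](C)(/C=C/c1ccc(Nc2ccc(Cl)cc2)cc1)CCC=C(C)C`. It differs from compound 1 in one place: (4-chlorophenyl)amino in place of methoxy on an aromatic carbon. Among the compounds with values here, no measured pair shows what such a change does in this assay, so there is no step to lean on. The expectation is that compound 4 stays close to where compound 1 stands, with a step of about an at least 1.4-fold lower number from compound 1 to compound 4 (0.16 log units; that floor lies within the scatter) that is not clearly beyond the scatter in either direction. Compound 4 is therefore estimated at 30000 nM, within a range from 5000 nM to 43400 nM.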

Compound 4, half-maximal effective concentration: > 43400 nM
Compound 4 ended at the assay's limit (the forecaster's own chance of this, stated with the estimate: 55%); middle value at least 1.4-fold (0.16 log units) from the limit.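

Within the data shown here, compound 1 and compound 4 both end at a limit in this assay rather than at a number, so no step between them can be read: the limit of > 43400 nM in this assay, at which 3 of the 4 values shown sit. The compounds shown leave open whether (4-chlorophenyl)amino in place of methoxy changes cytotoxicity at all.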